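This account rests on a few compounds, and the source may have more. Where it says the series, first, only, none or still open, it means among the compounds named here.

Of the compounds shown here, three built on one shared core have been tested in a functional assay on DU-145 cells (Homo sapiens) for cytotoxicity, read by MTT assay, with a stated time of 48 h; a higher number here means a weaker inhibitor, a lower number a stronger inhibitor. Compound 1 `Cc1ccc(S(=O)(=O)/N=C(/CCNC2=CC(=O)c3ccccc3C2=O)Nc2ccc(F)cc2)cc1` carries a 4-fluorophenyl on its amine nitrogen and gives 12200 nM. Compound 2 `Cc1ccc(S(=O)(=O)/N=C(/CCNC2=CC(=O)c3ccccc3C2=O)Nc2ccccc2[N+](=O)[O-])cc1` carries a 2-nitrophenyl on that nitrogen and gives 7590 nM. Compound 3 `Cc1ccc(S(=O)(=O)/N=C(/CCNC2=CC(=O)c3ccccc3C2=O)Nc2ccc(F)c(F)c2)cc1` carries a 3,4-difluorophenyl on that nitrogen and gives 12900 nM. Compound 3 sits level with the other two: a 1.1-fold higher number from compound 1 to compound 3 (0.02 log units; within the scatter) and a 1.7-fold higher number from compound 2 to compound 3 (0.23 log units; within the scatter) both stay within the scatter, and so does a 1.6-fold lower number from compound 1 to compound 2 (0.21 log units; within the scatter). Every exchange of the aryl group on the amine nitrogen seen so far has therefore left the number in this assay essentially where it was.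

Compound 4 `COc1ccc(N/C(CCNC2=CC(=O)c3ccccc3C2=O)=N\S(=O)(=O)c2ccc(C)cc2)c(OC)c1` continues this series with 2,4-dimethoxyphenyl in place of 3,4-difluorophenyl on an amine nitrogen. Within the data shown here, no measured pair involves a methoxy group, so the only guides are the three aryl exchanges already described, none of which moved the number beyond the scatter. On that basis compound 4 is expected to show no step beyond the scatter, that is a 1.2-fold lower number from compound 3 to compound 4 (0.07 log units; within the scatter). Compound 4 is therefore estimated at 11000 nM in this assay, within an expected range from 5000 nM to 25000 nM.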

Compound 4, half-maximal inhibitory concentration: 67300 nM
Beside the measured number, compound 4's estimate is 6.1-fold (0.79 log units) below it; measured number above the stated range.
By their numbers in this assay, from the lowest: compounds 2, 1 and 3 (each within the scatter of the next); then compound 4.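

Among these compounds, the aryl group on this amine nitrogen is not a freely exchangeable position in this assay: 2,4-dimethoxyphenyl gives the first changes beyond the scatter, with a 5.2-fold higher number from compound 3 to compound 4 (0.72 log units; beyond the scatter) and a 5.5-fold higher number from compound 1 to compound 4 (0.74 log units; beyond the scatter) and also an 8.9-fold higher number from compound 2 to compound 4 (0.95 log units; beyond the scatter) in the same direction, towards a weaker inhibitor. The earlier exchanges among 4-fluorophenyl, 2-nitrophenyl and 3,4-difluorophenyl showed no such tolerance limit, so this change shows that the aryl group can affect the result and that compound 4 stands apart from the other three compounds. The entering group also brings two oxygen atoms and two hydrogen-bond acceptors where 3,4-difluorophenyl has none, but nothing available explains why the number rises.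

The two methoxy groups arrive together in compound 4, so the compounds shown cannot tell whether one of them alone would produce this change or whether both are needed. A phenyl carrying a single methoxy group, or one carrying a hydroxyl or an amine, would help show whether the loss follows the methoxy groups specifically or extends to other groups containing oxygen or nitrogen.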